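The compounds below may be only part of what the source reports. "The series", "measured", "known", "first", "only" and "open" are said of these compounds alone.

Series notes. Three amides on the shared core have been run in an ADME assay on HEK293 cells (Homo sapiens) for cytotoxicity, read by CCK-8 assay, with a stated time of 48 h; on this read-out higher numbers stand for weaker inhibition and lower numbers for stronger inhibition. Compound 1 `Cc1nnsc1C(=O)Nc1nc2cc(F)ccc2o1` gives 42000 nM in this assay. Compound 2 `Cc1nnsc1C(=O)Nc1nc2ccccc2s1` returns only > 100000 nM in this assay, which is a limit of the assay and not a number. Compound 3 `O=C(Nc1nc2ccccc2o1)c1ccco1` likewise returns > 100000 nM in this assay, again a limit rather than a number. Compound 3 therefore stands at the upper edge of what this assay reports, and the limit of > 100000 nM in this assay, at which 2 of the 3 values shown sit, shows that it shares that position with one other member of the set. Within the data shown here, no pair of the measured compounds differs in a single place, so no measured step is available to guide the next one.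

Compound 4 `O=C(Nc1nc2ccccc2o1)c1ccccc1` is the next member to be measured in this assay. It differs from compound 3 by phenyl in place of furan-2-yl on a carbonyl carbon. With compound 3 at a limit, the step from there to compound 4 cannot be read as a number, and no change beyond the scatter is expected in this assay. The step from compound 3 to compound 4 is expected to be a number no higher from compound 3 to compound 4 (the limit leaves the size open). Compound 4 is estimated at 100000 nM in this assay, with a range from 40000 nM to 250000 nM, and a limit rather than a number is judged the more likely outcome.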

Compound 4, half-maximal inhibitory concentration: > 100000 nM
Compound 4 was reported as a limit; the forecaster's own chance of this, stated with the estimate: 70%; the middle value lies on the limit itself.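

Compound 3 and compound 4 both return only a limit in this assay, so the step between them cannot be read. The result joins the others at the same edge: the limit of > 100000 nM in this assay, at which 3 of the 4 values shown sit.

The compounds shown leave open whether phenyl in place of furan-2-yl on a carbonyl carbon changes the read-out in this assay at all.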